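Swapping the aryl group on the hydrazone arm of compound 3

The source may report more compounds than this note shows. Statements on the series, on what has been measured and on what is new or still open speak of the compounds shown alone.

Compound 3, whose structure is `Cn1c(=O)c(=O)n(C2CCCC2)c2nc(N/N=C/c3cccc([N+](=O)[O-])c3)ncc21`, is tested in a functional assay on PC-3 cells (Homo sapiens) for antiproliferative activity, read by MTT assay (on this read-out lower numbers stand for stronger inhibition and higher numbers for weaker inhibition), where compound 3 gives 20300 nM. Among the two numbers that exist, compound 3 carries the lowest, and its nearest neighbour is compound 2, with structure `COc1ccc(/C=N/Nc2ncc3c(n2)n(C2CCCC2)c(=O)c(=O)n3C)cc1`, for which compound 2 gives 26300 nM; the two lie within the usual scatter, so a 1.3-fold lower number from compound 2 to compound 3 (0.11 log units; within the scatter). Compound 1, with structure `COc1ccc(/C=N/Nc2ncc3c(n2)n(C2CCCC2)c(=O)c(=O)n3C)c(OC)c1`, gives only a limit of the assay, since compound 1 shows > 100000 nM. For the measured compounds named here, that limit, (the limit of > 100000 nM in this assay, at which 1 of the 3 values shown sits), is the single further value, and removing one methoxy group gives an at least 3.8-fold lower number from compound 1 to compound 2 (0.58 log units; beyond the scatter).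

Compound 4, with structure `CSc1ccc(/C=N/Nc2ncc3c(n2)n(C2CCCC2)c(=O)c(=O)n3C)cc1`, has not yet been measured. The change from compound 3 to compound 4 is 4-(methylsulfanyl)phenyl in place of 3-nitrophenyl on a carbon with a double bond to nitrogen. Going by the values given here, the only measured step that exchanges one aryl group for another on this carbon, a 1.3-fold lower number from compound 2 to compound 3 (0.11 log units; within the scatter), stayed within the scatter, and compound 4 carries, like compound 2, a single group on a phenyl ring rather than the two groups of compound 1. A step of similar smallness is therefore expected, a 1.1-fold higher number from compound 3 to compound 4 (0.03 log units; within the scatter), in either direction or none. Compound 4 is accordingly expected to give about 22000 nM, between 7000 nM and 70000 nM.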

Compound 4, half-maximal inhibitory concentration: 21000 nM
For compound 4 the middle estimate is 1.0-fold (0.02 log units) above the measured one; low and high end bracket the measured number.
By their numbers in this assay, from the lowest: compounds 3, 4 and 2 (each within the scatter of the next). At a limit, above all of these: compound 1.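

In this assay, the 3-nitrophenyl and 4-(methylsulfanyl)phenyl groups cannot be told apart on this carbon, with a 1.0-fold higher number from compound 3 to compound 4 (0.01 log units; within the scatter), even though they are different groups that differ in heavy atoms and hydrogen-bond acceptors. The narrower swap of one single group for another on the phenyl ring also stays within the scatter, with a 1.3-fold lower number from compound 2 to compound 4 (0.10 log units; within the scatter), so compounds 2, 3 and 4, each with a single group on the phenyl ring, now form a set of three with no separable order, and compound 1, with its 2,4-dimethoxyphenyl, is the one that goes against this. That exception is confirmed by an at least 4.7-fold lower number from compound 1 to compound 4 (0.67 log units; beyond the scatter), a step whose true size stays open, since compound 1 stands at a limit of the assay rather than at a number: the limit of > 100000 nM in this assay, at which 1 of the 4 values shown sits.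

From the compounds shown here alone, whether a plain phenyl, or a phenyl carrying an amine or a carboxylic acid, would fall in with compounds 2, 3 and 4 remains open, as does a longer chain on the sulfur in place of methyl. Changes to the shared core are also left open.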